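Shrinking the ring amine on the shared core

The compounds below may be only part of what the source reports. "The series", "measured", "known", "first", "only" and "open" are said of these compounds alone.

Compounds measured so far:
Compound 1 `O=C(CCc1ccc(C(F)(F)F)cc1)Nc1ccc2nc(N3CCCCCC3)ccc2c1`: 1800 nM
Compound 2 `CCN(CC)c1ccc2cc(NC(=O)CCc3ccc(C(F)(F)F)cc3)ccc2n1`: 830 nM
Compound 3 `O=C(CCCCCCCCCCCCc1ccc(C(F)(F)F)cc1)Nc1ccc2nc([N+]34CCC(CC3)CC4)ccc2c1`: 25 nM

In a functional assay on HEK293 cells for activation of melanin-concentrating hormone receptor 1 (Rattus norvegicus), read by inositol phosphate accumulation (on this read-out lower numbers stand for an effect already at smaller amounts and higher numbers for an effect only at larger amounts of compound), compound 1 gives the highest number of the three, with compound 2 nearest and compound 3 furthest away. Compound 4 `CC1CCN(c2ccc3cc(NC(=O)CCc4ccc(C(F)(F)F)cc4)ccc3n2)C1` differs from compound 1 in one place: 3-methylpyrrolidin-1-yl in place of azepan-1-yl on an aromatic carbon. Among the compounds with values here, the only step that bears on this change is a 2.2-fold lower number from compound 1 to compound 2 (0.34 log units; beyond the scatter), where another amine took the place of azepan-1-yl at the same position. A modest downward step is therefore expected for compound 4, roughly a 1.8-fold lower number from compound 1 to compound 4 (0.26 log units; within the scatter). Compound 4 is estimated at 1000 nM, within a range from 400 nM to 2500 nM.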

Compound 4, half-maximal effective concentration: 400 nM
Compound 4: the middle estimate sits 2.5-fold (0.40 log units) above what was measured; the measured number falls inside the stated range.
By their numbers in this assay, from the lowest: compound 3; then compound 4; then compound 2; then compound 1.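

Swapping the seven-membered azepan-1-yl ring for the five-membered 3-methylpyrrolidin-1-yl ring gives a 4.5-fold lower number from compound 1 to compound 4 (0.65 log units; beyond the scatter) and shows that this position responds to ring size as well as to a change of amine. The same ring also outdoes the open-chain diethylamino group, with a 2.1-fold lower number from compound 2 to compound 4 (0.32 log units; beyond the scatter) and thus the lowest number among these three amines. The data offer no explanation for this order. As far as these compounds go, it remains open what the methyl group itself contributes, which unsubstituted pyrrolidin-1-yl could show. Where the six-membered piperidin-1-yl would fall also remains unknown.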